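The compounds below may be only part of what the source reports. "The series", "measured", "known", "first", "only" and "open" are said of these compounds alone.

In a functional assay on HepG2 cells (Homo sapiens) for cytotoxicity, read by MTT assay, with a stated time of 72 h (a lower number here means a stronger inhibitor, a higher number a weaker inhibitor), compound 3 `O=c1cc(-c2ccccc2)oc2c(OCCCN3CCCC3)c(OCc3ccccc3)cc(O)c12` gives 2660 nM, the second highest of three numbers. Compound 2 `COc1c(OCCCCN2CCN(C)CC2)cc(O)c2c(=O)cc(-c3ccc([N+](=O)[O-])cc3)oc12` gives 2620 nM and compound 1 `COc1ccc(-c2cc(=O)c3c(O)cc(OCCCCN4CCN(C)CC4)c(OC)c3o2)cc1` gives 4200 nM, and both lie within the scatter of compound 3. Among the measured compounds shown here, the only measured step, a 1.6-fold lower number from compound 1 to compound 2 (0.20 log units; within the scatter), concerns a different change, nitro in place of methoxy on an aromatic carbon. Compound 4 `CN1CCN(CCCCOc2c(OCc3ccccc3)cc(O)c3c(=O)cc(-c4ccccc4)oc23)CC1` differs from compound 3 by (4-methylpiperazin-1-yl)methyl in place of pyrrolidin-1-yl on a saturated chain carbon, three bonds along the chain from an oxygen on an aromatic ring, so its chain becomes the 4-(4-methylpiperazin-1-yl)butyl that compounds 1 and 2 also carry. For the measured compounds named here, no measured step covers this change, and the three measured numbers sit together, so a step of a 1.0-fold higher number from compound 3 to compound 4 (0.01 log units; within the scatter) with no size beyond the scatter is expected. Compound 4 is estimated at 2700 nM, between 1200 nM and 6000 nM.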

Compound 4, half-maximal inhibitory concentration: 1500 nM
For compound 4 the middle estimate is 1.8-fold (0.26 log units) above the measured one; the measured number falls inside the stated range.
By their numbers in this assay, from the lowest: compounds 4, 2, 3 and 1 (each within the scatter of the next, the first and the last beyond it).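

this assay gives the first reading for this position, the end of the chain on the oxygen: a 1.8-fold lower number from compound 3 to compound 4 (0.25 log units; within the scatter). Exchanging 3-(pyrrolidin-1-yl)propyl for 4-(4-methylpiperazin-1-yl)butyl therefore leaves the two compounds indistinguishable here, so this site accepts the larger ring and the longer chain together. No available evidence accounts for the size of this step.

From the compounds shown here alone, the ring and the chain length changed at once, so their separate contributions remain open. A 4-(pyrrolidin-1-yl)butyl chain would pull them apart, and a morpholine ring on the same chain would test another amine.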